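Swapping fluoro for phenyl: an expected shift in growth inhibition

This account rests on a few compounds, and the source may have more. Where it says the series, first, only, none or still open, it means among the compounds named here.

Three compounds have been measured in a functional assay on MT2 cells (Homo sapiens) for antiproliferative activity, read by MTT assay, with a stated time of 72 h; a higher number here means a weaker inhibitor of growth, a lower number a stronger inhibitor of growth:

- compound 1 `O=C(COc1ccc2c(=O)cc(-c3ccccc3)oc2c1)Nc1ccc2ccccc2c1` gives > 10000 nM as a limit, not a number
- compound 2 `O=C(COc1ccc2c(=O)c(-c3ccccc3)coc2c1)Nc1ccc2ccccc2c1` gives 7680 nM as a number
- compound 3 `O=C(COc1ccc2c(=O)cc(-c3ccccc3)oc2c1)Nc1ccc(F)cc1` gives 6410 nM as a number

Within the data shown here, compound 3 and compound 2 hold the only two true numbers, and these lie within the scatter of each other. Compound 4 `O=C(COc1ccc2c(=O)cc(-c3ccccc3)oc2c1)Nc1ccc(-c2ccccc2)cc1` has not yet been measured. It keeps the rest of compound 3 but carries phenyl in place of fluoro on an aromatic carbon, para to a large group (phenyl in place of fluoro on an aromatic carbon).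

Among the measured compounds shown here, one measured step bears on this change, and it concerns a different group on the amide nitrogen. Going from naphthalen-2-yl to 4-fluorophenyl gives an at least 1.5-fold lower number from compound 1 to compound 3 (0.19 log units; that floor lies within the scatter), so its size is known only as a floor. Compound 4 moves back toward a bigger group, so a modest rise in the number is expected, perhaps no larger than the scatter, and a limit is also possible. The estimate means an expected 1.4-fold higher number from compound 3 to compound 4 (0.15 log units; within the scatter) in this assay. Compound 4 is estimated at 9000 nM, with 3500 nM to 20000 nM as the expected range.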

Compound 4, concentration for 50% growth inhibition: 2480 nM
The estimate for compound 4 lay 3.6-fold (0.56 log units) above the measured number; the whole stated range lies above it.
By their numbers in this assay, from the lowest: compound 4; then compounds 3 and 2 (each within the scatter of the next). At a limit, above all of these: compound 1.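

In this assay, replacing fluoro with phenyl on an aromatic carbon, para to a large group, gives a 2.6-fold lower number from compound 3 to compound 4 (0.41 log units; beyond the scatter), a modest step but one beyond the scatter. This is the first step among these compounds that is both a measured number and beyond the scatter, and it shows that this position can carry a second aromatic ring with stronger growth inhibition rather than weaker. The count of heavy atoms on the amide nitrogen's aromatic group therefore does not alone set the result, yet compound 1, with naphthalen-2-yl there, is held only at a limit, so how far it lies from the others cannot be read: the limit of > 10000 nM in this assay, at which 1 of the 4 values shown sits.

From the compounds shown here alone, whether the gain belongs to phenyl itself or would extend to other groups on the same carbon remains open, and a methoxy group, a morpholine ring or a carboxylic acid there would help to separate these possibilities. Also open, going by these compounds, is whether the same change would lower the number on the core of compound 2.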